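Indazolylmethyl diazepinedione series: amide-nitrogen substituent change

The source may hold more compounds than are shown below. What is called first, only, known or untested is meant among the compounds shown, and "the series" means these compounds.

Measured compounds in a functional assay on CHO cells for agonist activity at Melanocyte-stimulating hormone receptor (Homo sapiens), read by a luciferase reporter, with a stated time of 4 h; on this read-out higher numbers stand for an effect only at larger amounts of compound and lower numbers for an effect already at smaller amounts:
compound 1 `CCn1nc(CC2(OC)C(=O)N(CC(=O)N(c3ccc(OC)cc3)C(C)C)C=CN(c3ccccc3)C2=O)c2ccccc21` gives 31600 nM; > 30000 nM (2 entries)
compound 2 `COc1ccc(N(C(=O)CN2C=CN(c3ccccc3)C(=O)C(Cc3n[nH]c4ccccc34)C2=O)C(C)C)cc1` gives 29.5 nM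
compound 3 `COc1ccc(N(C(=O)CN2C=CN(c3ccccc3)C(=O)C(Cc3n[nH]c4ccccc34)(OC)C2=O)C(C)C)cc1` gives 1380 nM.

For compound 1 the entries in this assay are in part limits of the assay rather than numbers, as the several entries the several entries of compound 1 in this assay, 31600 nM; > 30000 nM (2 entries) show. Among the two compounds with a single number, compound 3 stands at the higher end: a 47-fold higher number from compound 2 to compound 3 (1.67 log units; beyond the scatter), a large step, and the only measured step in the set.

Compound 4 `COc1ccc(N(C(=O)CN2C=CN(Cc3cccs3)C(=O)C(Cc3n[nH]c4ccccc34)(OC)C2=O)C(C)C)cc1` is not yet measured. It differs from compound 3 in one place: (thiophen-2-yl)methyl in place of phenyl on an amide-type nitrogen in a ring. Within the data shown here, no measured step touches this position; the one step available concerns the methoxy on the saturated ring carbon, which compound 3 and compound 4 share. There is therefore no direct basis for the direction of the change, and only a moderate step beyond the scatter is expected, if any.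

For compound 4 the estimated value in this assay is 2500 nM, with a range from 500 nM to 15000 nM. This estimate means a step of a 1.8-fold higher number from compound 3 to compound 4 (0.26 log units; within the scatter), expected to be small.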

Compound 4, half-maximal effective concentration: 1170 nM
Estimate against measurement, compound 4: 2.1-fold (0.33 log units) above; measured number inside the range.
By their numbers in this assay, from the lowest: compound 2; then compounds 4 and 3 (each within the scatter of the next).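

At the amide-type nitrogen in the ring, (thiophen-2-yl)methyl in place of phenyl gives in this assay a 1.2-fold lower number from compound 3 to compound 4 (0.07 log units; within the scatter) and so cannot be told apart from phenyl on this read-out. Among these compounds, this position therefore accepts a five-membered aromatic ring with 1 hetero atom in place of a six-membered aromatic ring of carbon only, at least with the methoxy on the saturated ring carbon present, whereas the only earlier step, a 47-fold higher number from compound 2 to compound 3 (1.67 log units; beyond the scatter), concerned that methoxy. Nothing in the data shown bears on this result.

From the compounds shown here alone, whether the same exchange holds with hydrogen in place of the methoxy, as in compound 2, remains open. Also open, going by these compounds, is how an amine, a carboxylic acid or a longer chain such as 2-phenylethyl would read on this ring nitrogen.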